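The source may report more compounds than this note shows. Statements on the series, on what has been measured and on what is new or still open speak of the compounds shown alone.

In an ADME assay on Huh-7 cells (Homo sapiens) for cytotoxicity (a lower number here means that less compound is tolerated, a higher number that more compound is tolerated), compound 2 `Cc1ccccc1-c1nn(-c2ccc(F)cc2F)cc1CNCCN1CCN(C)CC1` gives > 20000 nM, which is a limit of the assay rather than a number. Compound 1 `Cc1ccccc1-c1nn(-c2ccc(Cl)cc2)cc1CNCCN1CCN(C)CC1` gives 17000 nM in this assay. Compound 3 `Cc1ccccc1-c1nn(-c2ccc(F)cc2F)cc1CNCCCCO` gives > 20000 nM, again a limit. Compound 4 `Cc1ccccc1-c1nn(-c2cccc(Cl)c2)cc1CNCCN1CCN(C)CC1` differs from compound 2 by 3-chlorophenyl in place of 2,4-difluorophenyl on an aromatic nitrogen. Among the measured compounds shown here, the one measured step that also swaps the aryl group on the aromatic nitrogen is an at least 1.1-fold higher number from compound 1 to compound 2 (0.07 log units; that floor lies within the scatter), and its reading is capped by the limit of > 20000 nM in this assay, at which 2 of the 3 values shown sit; the step that the two limits leave unreadable from compound 2 to compound 3 alters a different part and bears little on this change. Compound 4 is therefore expected to show a number no higher from compound 2 to compound 4 (the limit leaves the size open), nothing beyond the scatter. The estimate for compound 4 is 20000 nM, with a range from 11000 nM to 40000 nM, and a limit is the likelier report.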

Compound 4, half-maximal cytotoxic concentration: 16000 nM
For compound 4 the middle estimate is 1.3-fold (0.10 log units) above the measured one; the measured number falls inside the stated range.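

In this assay the change from 4-chlorophenyl to 3-chlorophenyl on the aromatic nitrogen gives a 1.1-fold lower number from compound 1 to compound 4 (0.03 log units; within the scatter) and so does not separate the two chlorophenyl groups. Against 2,4-difluorophenyl, 3-chlorophenyl gives an at least 1.2-fold lower number from compound 2 to compound 4 (0.09 log units; that floor lies within the scatter) and the true size stays open because that step starts from a limit: the limit of > 20000 nM in this assay, at which 2 of the 4 values shown sit.

The compounds shown leave open whether a plain phenyl or a 2-chlorophenyl group on the aromatic nitrogen would give a different number. They also leave open how either chlorophenyl group behaves alongside the chain of compound 3.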